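This account rests on a few compounds, and the source may have more. Where it says the series, first, only, none or still open, it means among the compounds named here.

Measured compounds:
compound 1, `Cn1c(-c2ccc(NC(=O)CCl)cc2)nc(-c2ccccc2)c1-c1ccccc1`, with 7.2% in a functional assay on HT-29 cells (Homo sapiens) for cytotoxicity, read by MTT assay, with a stated time of 24 h, tested at 0.64 ug/mL; a lower number here means a weaker effect, a higher number a stronger effect of the compound at the concentration tested;
compound 2, `Cn1c(-c2ccc(NC(=O)CSc3nc4ccccc4s3)cc2)nc(-c2ccccc2)c1-c1ccccc1`, with 9.8% in this assay.

Compound 2 gives the higher of the two numbers in this assay, but the gap to compound 1 is within the scatter, so the two compounds cannot be told apart on these data. Among the compounds with values here, the one measured step, a number 2.6 percentage points higher from compound 1 to compound 2 (within the scatter), replaced a chloro with a (1,3-benzothiazol-2-yl)sulfanyl on the saturated chain carbon bound to the carbonyl carbon and left the read-out essentially unchanged.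

Compound 3, `Cn1ccnc1SCC(=O)Nc1ccc(-c2nc(-c3ccccc3)c(-c3ccccc3)n2C)cc1`, has not been measured in this assay. It differs from compound 2 in this way: 1-methyl-1H-imidazol-2-yl in place of 1,3-benzothiazol-2-yl on a sulfur. Within the data shown here, the only step that bears on this change is a number 2.6 percentage points higher from compound 1 to compound 2 (within the scatter), which touched the same position and was within the scatter. On that basis no step beyond the scatter is expected in this assay for compound 3, in either direction, and the expected change from compound 2 is a number 0.8 percentage points lower from compound 2 to compound 3 (within the scatter). Compound 3 is therefore estimated at 9% in this assay, in a range from 2% to 17%.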

Compound 3, a percentage reported as activity, at one concentration (the size of the read-out at that concentration, not a potency): 13.6%
Compound 3: the middle estimate sits 4.6 percentage points below what was measured, and the stated range covers the measured number.
By their numbers in this assay, from the lowest: compounds 1, 2 and 3 (each within the scatter of the next).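

The change on the sulfur, 1-methyl-1H-imidazol-2-yl in place of 1,3-benzothiazol-2-yl, gives a number 3.8 percentage points higher from compound 2 to compound 3 (within the scatter) in this assay, so removing the six-membered aromatic ring of carbon only and adding the methyl-bearing imidazole ring does not separate the two compounds. The earlier step had tested only a swap of chloro for one sulfanyl group, whereas a number 6.4 percentage points higher from compound 1 to compound 3 (within the scatter) shows that a second sulfanyl group on the saturated chain carbon bound to a carbonyl carbon also stays within the scatter of chloro, and the position has so far produced no step beyond the scatter with any of the three groups shown. Nothing available explains the numbers of these three compounds.

As far as these compounds go, it remains open whether an amine, a carboxylic acid or a longer chain at this position would move the read-out beyond the scatter. Since the read-out comes from a single concentration, the three compounds also leave open how their potencies compare.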